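This account rests on a few compounds, and the source may have more. Where it says the series, first, only, none or still open, it means among the compounds named here.

Working notes on the series. The measure throughout is a functional assay on PC-3 cells (Homo sapiens) for antiproliferative activity, read by MTT assay, with a stated time of 24 h; a lower number here means a stronger inhibitor, a higher number a weaker inhibitor. Compound 1 `O=C1O/C(=C\Cn2cc(Cc3ccccc3)nn2)C(OCc2ccccc2)=C1OCc1ccccc1` gives 71300 nM in this assay. Compound 3 `Cc1ccc(-c2cn(C/C=C3\OC(=O)C(OCc4ccccc4)=C3OCc3ccccc3)nn2)cc1` returns only the assay limit, > 100000 nM. Compound 2 `O=C1NC(O)(CCn2cc(-c3ccccc3)nn2)C(OCc2ccccc2)=C1OCc1ccccc1` likewise returns only the assay limit, > 100000 nM. Compound 2 therefore stands at the floor of the numbers shown, where two of the three values sit (the limit of > 100000 nM in this assay, at which 2 of the 3 values shown sit), and no step away from it can be sized from the data. For the measured compounds named here, the single counted step, an at least 1.4-fold higher number from compound 1 to compound 3 (0.14 log units; that floor lies within the scatter), runs from a benzyl group on the triazole to an aryl group attached directly, and its floor lies within the scatter. Compound 4 `O=C1NC(O)(CCn2cc(Cc3ccccc3)nn2)C(OCc2ccccc2)=C1OCc1ccccc1` is the analogue of compound 2 with benzyl in place of phenyl on an aromatic carbon. This is the reverse direction of the move seen between compound 1 and compound 3: the directly attached aryl group gives way to a benzyl group. Compound 4 is thus expected at or somewhat under the limit, a step of an at least 1.1-fold lower number from compound 2 to compound 4 (0.04 log units; that floor lies within the scatter), with a real chance that only a limit is again returned. The estimate for compound 4 is 90000 nM, within 40000 nM to 200000 nM.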

Compound 4, half-maximal inhibitory concentration: > 100000 nM
Compound 4: no number, only a limit; the forecaster's own chance of this, stated with the estimate: 50%; middle value at least 1.1-fold (0.04 log units) away from the limit.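

Compound 2 and compound 4 both return only a limit, so no step between them can be read: the limit of > 100000 nM in this assay, at which 3 of the 4 values shown sit.

The compounds shown leave open whether benzyl in place of phenyl changes the result at all in this assay on the core of compound 2.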